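Swapping Fluoro for Chloro at One Aromatic Carbon

A few compounds are considered here, and "the series" means these few. Any claim that something is new, unique, unknown or untested is made for them only; others in the source may bear on it.

Compounds measured in an ADME assay on the whole organism for metabolic stability, with Rattus norvegicus as the target; on this read-out higher numbers stand for a longer-lived compound and lower numbers for a shorter-lived compound:
- compound 1 `O=S(=O)(c1ccc(O)c2ncccc12)C1CCCC1`: 0.18 h
- compound 2 `O=S(=O)(c1ccc(F)cc1)c1cc(Cl)c(O)c2ncccc12`: 8.9 h
- compound 3 `O=S(=O)(c1cc(F)c(O)c2ncccc12)C1CCCC1`: 7.7 h

Compound 3 stands at the top of this small set together with compound 2, since their two values lie within the scatter of each other. Compound 1 sits well apart from both. The next compound to be considered is compound 4 `O=S(=O)(c1cc(Cl)c(O)c2ncccc12)C1CCCC1`, which differs from compound 3 in one place: chloro in place of fluoro on an aromatic carbon. It carries chloro in place of fluoro on an aromatic carbon, ortho to a hydroxy group.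

Among the compounds with values here, only one measured step bears directly on that carbon. Fluoro in place of hydrogen there gave a 43-fold higher number from compound 1 to compound 3 (1.63 log units; beyond the scatter), a large step. Within the data shown here, no measured step exchanges one halogen for the other. Compound 2 does carry chloro on that carbon, though with a different group on the sulfonyl, and compound 2 shows 8.9 h. With a halogen already present in compound 3, and a chloro-bearing compound at a similar value, no further large move seems warranted. The expected result is a 1.1-fold higher number from compound 3 to compound 4 (0.04 log units; within the scatter), an estimated step that stays within the scatter. For compound 4 the estimated half-life is 8.5 h, with an expected range of 3.5 h to 20 h.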

Compound 4, half-life: 11 h
Compound 4: the middle estimate sits 1.3-fold (0.11 log units) below what was measured; the measured number falls inside the stated range.
By their numbers in this assay, from the lowest: compound 1; then compounds 3, 2 and 4 (each within the scatter of the next).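

In this assay, the exchange on this aromatic carbon, ortho to a hydroxy group, amounts to a 1.4-fold higher number from compound 3 to compound 4 (0.15 log units; within the scatter), so the compounds shown do not separate chloro from fluoro here, and what had been seen only for fluoro now also holds for chloro, which gives a large step over hydrogen (a 61-fold higher number from compound 1 to compound 4 (1.79 log units; beyond the scatter)). The group on the sulfonyl sulfur can also change with chloro in place, since the exchange of 4-fluorophenyl for cyclopentyl gives a 1.2-fold higher number from compound 2 to compound 4 (0.09 log units; within the scatter), and these two very different groups are not told apart at this half-life. Nothing available explains why either halogen stands so far from hydrogen at this carbon.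

The compounds shown leave open whether the large step belongs to halogens alone, or whether bromo, methyl, methoxy or a nitrile on the same carbon would also stand with compound 3 and compound 4 rather than with compound 1. They also leave open whether the sulfonyl group matters when hydrogen sits on that carbon, and whether a piperidine or a longer chain there would behave as cyclopentyl and 4-fluorophenyl do.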